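The source may report more compounds than this note shows. Statements on the series, on what has been measured and on what is new or still open speak of the compounds shown alone.

Measured so far in an ADME assay on MT4 cells (Homo sapiens) for cytotoxicity, read by MTT assay, with a stated time of 96 h (a lower number here means that less compound is tolerated, a higher number that more compound is tolerated), as follows
- compound 1 `CC(=O)c1ccc2c(c1)nc(-c1ccc(Cl)cc1)n2C1CCCCC1` gives 58000 nM
- compound 2 `C/C(=N\NC(N)=S)c1ccc2c(c1)nc(-c1ccccc1)n2C1CCCCC1` gives 20000 nM

Compound 2 holds the lower of the two numbers, and its gap to compound 1 lies beyond the scatter. These two compounds differ in more than one place, so neither value isolates a single structural change. Compound 3 `C/C(=N\NC(N)=S)c1ccc2c(c1)nc(-c1ccc(Cl)cc1)n2C1CCCCC1` arises from compound 2 through chloro in place of hydrogen on an aromatic carbon as chloro in place of hydrogen on an aromatic carbon, para to a large group. Going by the values given here, no measured pair shows this change, so the expectation remains loose, with a wide range around the value of compound 2. No step beyond the scatter is expected, with only a slight lean towards a lower number. The estimated change is a 1.4-fold lower number from compound 2 to compound 3 (0.15 log units; within the scatter) and should stay small. In this assay the expected value for compound 3 is 14000 nM (estimated range 6000 nM to 35000 nM).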

Compound 3, half-maximal cytotoxic concentration: 17000 nM
The estimate for compound 3 lay 1.2-fold (0.08 log units) below the measured number; the measured number falls inside the stated range.
By their numbers in this assay, from the lowest: compounds 3 and 2 (each within the scatter of the next); then compound 1.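

In this assay the change from phenyl to 4-chlorophenyl, para to a large group, gives a step within the scatter (a 1.2-fold lower number from compound 2 to compound 3 (0.07 log units; within the scatter)), so chloro in place of hydrogen at this place has no readable effect on this number when the larger side group is present. With 4-chlorophenyl held constant, the group of 7 heavy atoms in place of the group of 3 heavy atoms on an aromatic carbon gives a modest step beyond the scatter (a 3.4-fold lower number from compound 1 to compound 3 (0.53 log units; beyond the scatter)), which locates the readable change in that side group rather than at the chloro position. Nothing available explains the size of either step.

On these data alone, whether a methoxy group or an amine at the chloro position would also stay within the scatter remains open. So does which part of the larger side group carries its step, for instance whether oxygen in place of its sulfur would keep it.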